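A few compounds are considered here, and "the series" means these few. Any claim that something is new, unique, unknown or untested is made for them only; others in the source may bear on it.

Working notes on the series, read in an ADME assay on HepG2 cells (Homo sapiens) for cytotoxicity, read by luminescence, CellTiter-Glo and ATP content, with a stated time of 72 h; a higher number here means that more compound is needed for the effect, a lower number that less compound is needed. Compound 1 `CN(C)c1cccc(Oc2ccc3c(NCCCNCc4ccco4)ccnc3c2)c1` gives 16000 nM. Compound 2 `COc1ccc(F)cc1CNCCCNc1ccnc2cc(Oc3cccc(N(C)C)c3)ccc12` gives 3300 nM, and compound 3 `COc1cccc(CNCCCNc2ccnc3cc(Oc4cccc(N(C)C)c4)ccc23)c1O` gives 7300 nM. Compound 2 stands lowest of the three numbers, with a 2.2-fold higher number from compound 2 to compound 3 (0.34 log units; beyond the scatter) and a 4.8-fold lower number from compound 1 to compound 2 (0.69 log units; beyond the scatter); the remaining measured step is a 2.2-fold lower number from compound 1 to compound 3 (0.34 log units; beyond the scatter). Every measured step alters the group on the saturated chain carbon bound to an amine nitrogen; none alters the aryl ether. Compound 4 `COc1ccc(F)cc1CNCCCNc1ccnc2cc(Oc3ccc(Cl)cc3)ccc12` differs from compound 2 at that ether: 4-chlorophenyl in place of 3-(dimethylamino)phenyl on an oxygen on an aromatic ring. Within the data shown here, no measured step bears on this change, so the expectation rests on compound 2 alone, and the step is expected to read a 1.1-fold higher number from compound 2 to compound 4 (0.03 log units; within the scatter), not beyond the scatter. Compound 4 is expected at 3500 nM in this assay, within 1300 nM to 9000 nM.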

Compound 4, half-maximal effective concentration: 4500 nM
Beside the measured number, compound 4's estimate is 1.3-fold (0.11 log units) below it; low and high end bracket the measured number.
By their numbers in this assay, from the lowest: compounds 2, 4 and 3 (each within the scatter of the next, the first and the last beyond it); then compound 1.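

Among these compounds, the aryl ether is read here for the first time: in this assay, 4-chlorophenyl in place of 3-(dimethylamino)phenyl on an oxygen on an aromatic ring gives a 1.4-fold higher number from compound 2 to compound 4 (0.13 log units; within the scatter) with the 5-fluoro-2-methoxyphenyl group held. Every earlier step altered the group on the saturated chain carbon, so this position now has one reading, and in it the two groups are not told apart. No measurement at hand offers an explanation for this reading.

As far as these compounds go, whether the same exchange reads alike with furan-2-yl or 2-hydroxy-3-methoxyphenyl on the chain stays open. So does the reading of this ether with an unsubstituted phenyl, a morpholine or a carboxylic acid on the ring.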